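Swapping the boron group for a nitrile on compound 1

The compounds below may be only part of what the source reports. "The series", "measured", "known", "first", "only" and "open" are said of these compounds alone.

Measured so far:
- compound 1 `COc1cc2ncnc(Nc3ccc(B(O)O)cc3)c2cc1OC`: 49%
- compound 2 `OB(O)c1ccc2ncnc(Nc3ccc(F)c(Cl)c3)c2c1`: "not active" (no number reported)
- compound 3 `COCCOc1cc2ncnc(Nc3cccc(B(O)O)c3)c2cc1OC`: 19%

In an assay on isolated protein for inhibition of vascular endothelial growth factor receptor 1 (Homo sapiens), read by ELISA, with a stated time of 20 min, tested at 1 uM (a lower number here means less inhibition, a higher number more inhibition at the concentration tested (going by the name of the read-out)), compound 1 gives 49%. Of the two numbers reported, this is the higher one; compound 3, with a different attachment of the boron group on its aniline ring, gives 19% in this assay, a gap beyond the usual scatter. Compound 2, which carries the boron group on the shared core instead, is reported in this assay only as "not active" (no number reported), without a number.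

The next compound, compound 4 `COc1cc2ncnc(Nc3ccc(C#N)cc3)c2cc1OC`, keeps the core of compound 1 and alters only the group on the aniline ring: a group of 2 heavy atoms (1 carbon, 1 nitrogen; no ring) in place of a group of 3 heavy atoms (1 boron, 2 oxygen; no ring), on an aromatic carbon. Among the measured compounds shown here, no measured pair shows what such a change does here, so the expectation can rest only on compound 1 itself. A modest fall is expected, with a number 9 percentage points lower from compound 1 to compound 4 (within the scatter) likely staying within the scatter. Compound 4 is therefore estimated at 40% in this assay, in a range from 10% to 70%.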

Compound 4, a percentage reported as inhibition, at one concentration (the size of the read-out at that concentration, not a potency): "not active" (no number reported)
For compound 4 the study gives words and no number; no gap can be computed for the estimate.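

Compound 4 is reported in words only, without a number; no step from compound 1 to compound 4 can be read, and nothing shown here explains the result. The compounds shown leave open how large the effect of replacing the boron group with a nitrile is on this core.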